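Working notes: aryl replacement by methylfuran at the cyano-flanked carbon

This account rests on a few compounds, and the source may have more. Where it says the series, first, only, none or still open, it means among the compounds named here.

Measured so far in a functional assay on aorta (Rattus norvegicus, strain Wister); on this read-out higher numbers stand for weaker inhibition and lower numbers for stronger inhibition:
- compound 1 `COc1nc(-c2nc3ccccc3n2C)cc(-c2ccc(Cl)cc2Cl)c1C#N`: 214000 nM
- compound 2 `COc1nc(-c2nc3ccccc3n2C)cc(-c2ccc(C)cc2)c1C#N`: 295000 nM
- compound 3 `COc1ccc(-c2cc(-c3nc4ccccc4n3C)nc(OC)c2C#N)cc1`: 210000 nM

Compound 3 gives the lowest of the three numbers, but its separation from the others is small: a 1.0-fold lower number from compound 1 to compound 3 (0.01 log units; within the scatter) and a 1.4-fold lower number from compound 2 to compound 3 (0.15 log units; within the scatter) both fall within the scatter, as does a 1.4-fold higher number from compound 1 to compound 2 (0.14 log units; within the scatter). All three measured steps exchange one six-membered aryl group for another at the same place, and none of them moves the read-out beyond the scatter.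

Compound 4 `COc1nc(-c2nc3ccccc3n2C)cc(-c2ccc(C)o2)c1C#N` is the next analogue: 5-methylfuran-2-yl in place of 4-methoxyphenyl on an aromatic carbon. Within the data shown here, no measured step tests a five-membered ring at this position, so the three aryl-to-aryl steps are the only guide, and they suggest a change of no more than the scatter. Compound 4 is therefore expected to give about 230000 nM, with a plausible range from 100000 nM to 550000 nM. The expected step is a 1.1-fold higher number from compound 3 to compound 4 (0.04 log units; within the scatter), which is within the scatter.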

Compound 4, half-maximal inhibitory concentration: 283000 nM
For compound 4 the middle estimate is 1.2-fold (0.09 log units) below the measured one; the measured number falls inside the stated range.
By their numbers in this assay, from the lowest: compounds 3, 1, 4 and 2 (each within the scatter of the next).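

In this assay, a five-membered aromatic ring with 1 hetero atom at this position is not separated from the six-membered aryl groups: a 1.3-fold higher number from compound 3 to compound 4 (0.13 log units; within the scatter), a 1.0-fold lower number from compound 2 to compound 4 (0.02 log units; within the scatter) and a 1.3-fold higher number from compound 1 to compound 4 (0.12 log units; within the scatter) all lie within the scatter. The flat picture at this position therefore extends beyond rings of carbon only, and to a group of 6 heavy atoms in place of the 8 of 4-methoxyphenyl. Nothing available accounts for this flat read-out.

Going by these compounds, all four groups at this position are aromatic rings, so it remains open whether a primary amine, a carboxylic acid or a longer alkyl chain there would move the number beyond the scatter. The cyano and methoxy groups are constant across these compounds, leaving their contribution to the read-out untested.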